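The source may report more compounds than this note shows. Statements on the series, on what has been measured and on what is new or still open speak of the compounds shown alone.

Working notes on the series.

Three compounds share the core of compound 1 `c1ccc2nc(COc3ccc(SCCCc4nnn[nH]4)cc3)ccc2c1`. In an assay on isolated protein for binding affinity to cysteinyl leukotriene receptor 1 (Cavia porcellus) (a higher number here means a weaker inhibitor, a lower number a stronger inhibitor), compound 1 gives 31 nM, the lowest of the three numbers. Compound 2 `c1cc(OCCCCc2nnn[nH]2)cc(OCc2ccc3ccccc3n2)c1` gives 75 nM in this assay, and compound 3 `CCOC(=O)CCCOc1cccc(OCc2ccc3ccccc3n2)c1` gives 160 nM. For the measured compounds named here, the only single-point step among the measured compounds is a 2.1-fold higher number from compound 2 to compound 3 (0.33 log units; beyond the scatter); it stays on the same side of the ring and touches only the chain end.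

Compound 4 `CCOC(=O)CCCOc1ccc(OCc2ccc3ccccc3n2)cc1` has not been measured in this assay. It differs from compound 1 as follows: a group of 9 heavy atoms (6 carbon, 3 oxygen; no ring) in place of a group of 9 heavy atoms (4 carbon, 4 nitrogen, 1 sulfur; one five-membered aromatic ring with 4 hetero atoms), on an aromatic carbon. The change thus removes the five-membered aromatic ring with 4 hetero atoms together with its sulfur and puts in the 3-(ethoxycarbonyl)propoxy group, on an aromatic carbon para to a large group. Going by the values given here, the step from compound 2 to compound 3 bears most directly on this, since it also exchanges the tetrazole end for an ethoxycarbonyl end and cost a modest rise; the sulfur-to-oxygen part of the present change has no measured counterpart here. For compound 4 a rise of similar size is therefore expected, a 2.3-fold higher number from compound 1 to compound 4 (0.35 log units; beyond the scatter), though the range is kept wide. The estimate for compound 4 in this assay is 70 nM, between 30 nM and 170 nM.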

Compound 4, inhibition constant: 500 nM
The estimate for compound 4 lay 7.1-fold (0.85 log units) below the measured number; the whole stated range lies below it.
By their numbers in this assay, from the lowest: compound 1; then compound 2; then compound 3; then compound 4.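

In this assay, on an aromatic carbon para to a large group, 3-(ethoxycarbonyl)propoxy in place of the sulfur-linked chain ending in the five-membered aromatic ring with 4 hetero atoms gives a 16-fold higher number from compound 1 to compound 4 (1.21 log units; beyond the scatter), a large step, whereas the earlier exchange of that ring end for an ethoxycarbonyl end gave only a 2.1-fold higher number from compound 2 to compound 3 (0.33 log units; beyond the scatter). The modest cost seen earlier therefore does not carry over in size to this change, which also removes the sulfur and the hydrogen-bond donor of the leaving group, so it is not a measure of the chain end alone. Nothing available explains the size of this step.

The compounds shown do not separate the contribution of the sulfur from that of the chain end, since none at this position pairs the sulfur with an ethoxycarbonyl end or an oxygen link with the tetrazole end. On these data alone, how a carboxylic acid at the chain end, or a longer chain at this position, would read in this assay also remains open.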